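Aryloxy variation on the shared core: outlook for compound 4

A few compounds are considered here, and "the series" means these few. Any claim that something is new, unique, unknown or untested is made for them only; others in the source may bear on it.

The shared core of compound 1 `Cc1cccc(Nc2ncc(Br)c(Oc3cccc(F)c3)n2)c1` carries differing aryloxy groups. In a functional assay on MCF7 cells (Homo sapiens) for antiproliferative activity, read by MTT assay, with a stated time of 24 h (on this read-out lower numbers stand for stronger inhibition and higher numbers for weaker inhibition), compound 1 gives 26800 nM. Compound 2 `Cc1cccc(Nc2ncc(Br)c(Oc3cc(Cl)cc(Cl)c3)n2)c1` gives > 50000 nM in this assay, a limit of the assay and not a number (the limit of > 50000 nM in this assay, at which 1 of the 3 values shown sits). Compound 3 `Cc1cccc(Nc2ncc(Br)c(Oc3ccc(Br)cc3)n2)c1` gives 19100 nM, the lower of the two numbers shown; the step of a 1.4-fold lower number from compound 1 to compound 3 (0.15 log units; within the scatter) stays within the scatter, while an at least 2.6-fold lower number from compound 2 to compound 3 (0.41 log units; beyond the scatter) is the one step beyond it. Compound 4 `Cc1cccc(Nc2ncc(Br)c(Oc3ccc(OCc4ccccc4)cc3)n2)c1` differs from compound 3 in benzyloxy in place of bromo on an aromatic carbon. The measured steps all vary the aryloxy group but none at this place, so they bear only loosely; with an at least 1.8-fold higher number from compound 1 to compound 2 (0.27 log units; that floor lies within the scatter) and a 1.4-fold lower number from compound 1 to compound 3 (0.15 log units; within the scatter) both small, a step of a 1.2-fold higher number from compound 3 to compound 4 (0.06 log units; within the scatter) is expected, none beyond the scatter. Compound 4 is estimated at 22000 nM, within 8000 nM to 60000 nM.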

Compound 4, half-maximal inhibitory concentration: > 50000 nM
Compound 4 ended at the assay's limit; the forecaster's own chance of this, stated with the estimate: 20%; middle value at least 2.2-fold (0.35 log units) away from the limit.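

Benzyloxy in place of bromo on this aromatic carbon gives an at least 2.6-fold higher number from compound 3 to compound 4 (0.41 log units; beyond the scatter), so a change at this place can move the read-out beyond the scatter. For compound 4 the value is a limit and not a number, so this step is only a floor: the limit of > 50000 nM in this assay, at which 2 of the 4 values shown sit. In this assay, bromo at this place keeps a measurable number, while benzyloxy does not.

Going by these compounds, whether methoxy, an amine or a carboxylic acid at this place would keep a measurable number remains open. Also open, on these data alone, is how far past the limit compound 4 lies.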